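This account rests on a few compounds, and the source may have more. Where it says the series, first, only, none or still open, it means among the compounds named here.

Measured so far in a functional assay on NPC-TW01 cells (Homo sapiens) for inhibition, read by MTT assay, with a stated time of 72 h; on this read-out higher numbers stand for weaker inhibition of growth and lower numbers for stronger inhibition of growth:
compound 1 `COC(=O)c1nc(C2CC2)n(-c2ccc(F)cc2)n1`: 95900 nM
compound 2 `COC(=O)c1nc(C2CCCCC2)n(-c2ccc(F)cc2)n1`: 30500 nM
compound 3 `COC(=O)c1nc(-c2ccsc2)n(-c2ccc(F)cc2)n1`: 10700 nM

Compound 3 gives the lowest number of the three, and its steps to the other two lie beyond the scatter, so it is the strongest inhibitor of growth so far: a 9.0-fold lower number from compound 1 to compound 3 (0.95 log units; beyond the scatter) and a 2.9-fold lower number from compound 2 to compound 3 (0.45 log units; beyond the scatter). Compound 4 `COC(=O)c1nc(-c2ccccc2)n(-c2ccc(F)cc2)n1` differs from compound 3 by phenyl in place of thiophen-3-yl on an aromatic carbon. For the measured compounds named here, no measured step exchanges one aromatic ring for another; the two aromatic-for-saturated steps above show only that an aromatic ring at this carbon gives a lower number than a saturated one. The exchange from compound 3 to compound 4 is therefore expected to give a small step, a 1.1-fold higher number from compound 3 to compound 4 (0.05 log units; within the scatter), not beyond the scatter in this assay. Compound 4 is estimated at 12000 nM, with a range from 5000 nM to 30000 nM.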

Compound 4, concentration for 50% growth inhibition: 15600 nM
The estimate for compound 4 lay 1.3-fold (0.11 log units) below the measured number, and the stated range covers the measured number.
By their numbers in this assay, from the lowest: compounds 3, 4 and 2 (each within the scatter of the next, the first and the last beyond it); then compound 1.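

In this assay, exchanging one aromatic ring for another at this carbon leaves the number within the scatter (a 1.5-fold higher number from compound 3 to compound 4 (0.16 log units; within the scatter)), so a ring of carbon only serves as well as thiophen-3-yl here. Phenyl stands clear of cyclopropyl (a 6.1-fold lower number from compound 1 to compound 4 (0.79 log units; beyond the scatter)) but not of cyclohexyl (a 2.0-fold lower number from compound 2 to compound 4 (0.29 log units; within the scatter)), so compound 4 goes against any general aromatic-over-saturated reading, and only compound 3 separates from cyclohexyl. No evidence is available that bears on these steps. Open, from the compounds shown here alone, is whether a ring with an amine, or a longer alkyl chain, at this carbon would lower the number, and whether a carboxylic acid in place of the methoxycarbonyl group would keep it.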